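The source may report more compounds than this note shows. Statements on the series, on what has been measured and on what is new or still open speak of the compounds shown alone.

Measured so far:
compound 1, `Oc1cccc(-c2cc(-c3cccnc3)nc(-c3ccccc3Cl)c2)c1`: 0%
compound 2, `Oc1cccc(-c2cc(-c3ccc(Cl)cc3)nc(-c3cccnc3)c2)c1`: 2.8%

In an assay on isolated protein for inhibition of DNA topoisomerase 1 (Homo sapiens), with a stated time of 30 min, tested at 100 uM (a lower number here means a weaker effect, a higher number a stronger effect of the compound at the concentration tested), compound 1 gives 0%, and compound 2 gives 2.8%; the two numbers lie within the scatter of one another, as the step of a number 2.8 percentage points higher from compound 1 to compound 2 (within the scatter) shows, so compound 1 shares the bottom of this short series rather than standing apart. Compound 3 `Oc1cccc(-c2cc(-c3ccccn3)nc(-c3ccccc3Cl)c2)c1` differs from compound 1 by pyridin-2-yl in place of pyridin-3-yl on an aromatic carbon. For the measured compounds named here, no measured step bears on this change: the single step, a number 2.8 percentage points higher from compound 1 to compound 2 (within the scatter), concerns another group and is itself within the scatter. Compound 3 is therefore expected to show no step beyond the scatter, no change at the digits printed from compound 1 to compound 3 (within the scatter). The estimated value of compound 3 is 0%, between -5% and 10%.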

Compound 3, a percentage reported as inhibition, at one concentration (the size of the read-out at that concentration, not a potency): 0%
Compound 3: the middle estimate sits on the measured number at the digits printed; the measured number falls inside the stated range.
By their numbers in this assay, from the lowest: compounds 1, 3 and 2 (each within the scatter of the next).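

In this assay, for the compounds shown here, the replacement of pyridin-3-yl by pyridin-2-yl on this aromatic carbon, a change that keeps the same atoms, gives no change at the digits printed from compound 1 to compound 3 (within the scatter) and is the first reading at this position. Compound 1 and compound 3 both sit at the bottom of the read-out, so this pair cannot say whether the place of the ring nitrogen would matter in a compound with a clear effect. From the compounds shown here alone, whether an amine or a carboxylic acid at this position would lift the number stays open. No evidence at hand accounts for the absence of a step here.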